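The source may report more compounds than this note shows. Statements on the series, on what has been measured and on what is new or still open speak of the compounds shown alone.

Measured so far in a functional assay on DU-145 cells (Homo sapiens) for inhibition, read by trypan blue exclusion, with a stated time of 96 h; on this read-out higher numbers stand for weaker inhibition of growth and lower numbers for stronger inhibition of growth:
- compound 1 `CCOc1ccc(/C=C(\C(=O)c2ccc(Cl)cc2)S(=O)(=O)Cc2ccc(C)cc2)cc1OC` gives 10000 nM
- compound 2 `COc1ccccc1/C=C(\C(=O)c1ccc(Cl)cc1)S(=O)(=O)c1ccc(Br)cc1` gives 10000 nM
- compound 3 `Cc1ccc(CS(=O)(=O)/C(=C/c2ccc(C)s2)C(=O)c2ccc(Cl)cc2)cc1` gives 25000 nM

Compound 3 stands highest of the three numbers on this assay; compounds 1 and 2 sit together at the same lower number, each a step beyond the scatter away from compound 3. Among the compounds with values here, the one single-point step measured is a 2.5-fold higher number from compound 1 to compound 3 (0.40 log units; beyond the scatter), a modest worsening when the thiophene group comes in.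

Compound 4 `COc1ccccc1/C=C(\C(=O)c1ccc(Cl)cc1)S(=O)(=O)Cc1ccc(C)cc1` has not yet been measured. It differs from compound 3 by 2-methoxyphenyl in place of 5-methylthiophen-2-yl on a double-bonded chain carbon bound to a double-bonded chain carbon. The step from compound 1 to compound 3 bears on this change in reverse: there, replacing a substituted phenyl group with 5-methylthiophen-2-yl raised the number, so returning to a substituted phenyl group is expected to lower it by about the same modest amount. Compound 2, which carries the same 2-methoxyphenyl group on a different sulfonyl partner, gives 10000 nM, in line with that. Compound 4 is therefore estimated at 10000 nM (range 4000 nM to 25000 nM), an expected step of a 2.5-fold lower number from compound 3 to compound 4 (0.40 log units; beyond the scatter).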

Compound 4, concentration for 50% growth inhibition: 10000 nM
Compound 4: the middle estimate sits on the measured number at the digits printed; the range from low to high includes it.
By their numbers in this assay, from the lowest: compounds 1, 2 and 4 (each within the scatter of the next); then compound 3.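

In this assay, 2-methoxyphenyl in place of 5-methylthiophen-2-yl gives a 2.5-fold lower number from compound 3 to compound 4 (0.40 log units; beyond the scatter), so a second phenyl group now separates from the thiophene at this place, as the 4-ethoxy-3-methoxyphenyl group did. The two phenyl groups themselves do not separate, with no change at the digits printed from compound 1 to compound 4 (within the scatter), and the change on the sulfonyl sulfur from 4-bromophenyl to 4-methylbenzyl gives no change at the digits printed from compound 2 to compound 4 (within the scatter), so neither change moves the number beyond the scatter. No measured evidence is available to explain these steps.

The compounds shown leave open whether any group on the double-bonded chain carbon, such as a phenyl group carrying an amine or a carboxylic acid, brings the number lower than that shared by compounds 1, 2 and 4. They also leave open whether a longer chain on the sulfonyl sulfur would move it.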